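Compound 4 after the pyridine of compound 3

This account rests on a few compounds, and the source may have more. Where it says the series, first, only, none or still open, it means among the compounds named here.

Compound 1 `COc1cccc(/C=C/C(=O)c2ccc(OC)c3c2OC(C)(C)C=C3)c1` gives 9360 nM
Compound 2 `COc1ccc(/C=C/C(=O)c2ccc(OC)c3c2OC(C)(C)C=C3)c(F)c1` gives 4880 nM
Compound 3 `COc1ccc(/C=C/C(=O)c2ccc(OC)c3c2OC(C)(C)C=C3)cn1` gives > 10000 nM as a limit, not a number

These results come from a functional assay on SK-OV-3 cells (Homo sapiens) for antiproliferative activity, read by MTT assay, with a stated time of 24 h (a lower number here means a stronger inhibitor, a higher number a weaker inhibitor), and the three compounds share one core. They differ only in the group on a double-bonded chain carbon bound to a double-bonded chain carbon. Compound 3 stands at the limit of > 10000 nM in this assay, at which 1 of the 3 values shown sits, and this is a limit, not a number.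

Compound 4 `COc1ccc(C(=O)/C=C/c2ccccc2Cl)c2c1C=CC(C)(C)O2` has the same core and carries 2-chlorophenyl in place of 6-methoxypyridin-3-yl (2-chlorophenyl in place of 6-methoxypyridin-3-yl on a double-bonded chain carbon bound to a double-bonded chain carbon). Going by the values given here, no measured compound carries 2-chlorophenyl, so the guide is indirect. Three measured steps changed the group at this place. One of them (an at least 2.0-fold higher number from compound 2 to compound 3 (0.31 log units; beyond the scatter)) lies beyond the scatter, and the other two (a 1.9-fold lower number from compound 1 to compound 2 (0.28 log units; within the scatter) and an at least 1.0-fold higher number from compound 1 to compound 3 (0.02 log units; that floor lies within the scatter)) do not.

Compound 4 has a ring of carbon only, as do the other two compounds. A result near compound 1 with 9360 nM and compound 2 with 4880 nM is therefore expected. The expected change is modest and points toward a lower number, a stronger result, as the estimated at least 1.6-fold lower number from compound 3 to compound 4 (0.22 log units; that floor lies within the scatter) shows. For compound 4 the estimated value is 6000 nM with an expected range from 2500 nM to 12000 nM in this measurement.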

Compound 4, half-maximal inhibitory concentration: > 10000 nM
Compound 4: no number, only a limit; the forecaster's own chance of this, stated with the estimate: 25%; at least 1.6-fold (0.22 log units) between middle value and limit.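

In this assay, going by these compounds alone, compound 4 joins compound 3 at a limit rather than a number: the limit of > 10000 nM in this assay, at which 2 of the 4 values shown sit. Compound 4 shows that the pyridine ring is not the only group at this place that gives such a limit, with an at least 2.0-fold higher number from compound 2 to compound 4 (0.31 log units; beyond the scatter) and an at least 1.0-fold higher number from compound 1 to compound 4 (0.02 log units; that floor lies within the scatter), while the step between compound 3 and compound 4 cannot be read. Compound 1 and compound 2 are the only two here with a readable number, and each carries a methoxy group on a ring of carbon only, whereas 2-chlorophenyl has the carbon-only ring without a methoxy group, so that ring alone did not give a readable number in compound 4.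

As far as these compounds go, it remains open whether the result of compound 4 goes with the missing methoxy group or with the chlorine, which a plain phenyl group at this place could help to separate. From the compounds shown here alone, it also remains open how a ring carrying an amine or a carboxylic acid would behave here, and how far compound 3 and compound 4 lie from each other.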